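The compounds below may be only part of what the source reports. "The series", "measured", "known", "first", "only" and "open" are said of these compounds alone.

Measured in a functional assay on ileum (Cavia porcellus) for antagonist activity, with a stated time of 30 s; a higher number here means a weaker inhibitor, a lower number a stronger inhibitor:
Compound 1 `O=C(O)c1cc(=O)c2c(OCCCCCOc3ccccc3)cccc2o1`: 17.5 ug/mL
Compound 2 `O=C(O)c1cc(=O)c2c(OCCCCCCCOc3ccccc3)cccc2o1`: 0.8 ug/mL

Of these two, compound 2 stands lowest at 0.8 ug/mL, which makes it the stronger inhibitor in this assay. Compound 3 `O=C(O)c1cc(=O)c2c(OCCCCCCCCCOc3ccccc3)cccc2o1` has not yet been measured. It differs from compound 2 as follows: 2-phenoxyethyl in place of phenoxy on a saturated chain carbon, seven bonds along the chain from an oxygen on an aromatic ring. In words, 2-phenoxyethyl stands in place of phenoxy on a saturated chain carbon, seven bonds along the chain from an oxygen on an aromatic ring.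

Going by the values given here, only one measured step bears on this change. The same replacement, made five bonds along the chain, gave a 22-fold lower number from compound 1 to compound 2 (1.34 log units; beyond the scatter), a large step beyond the scatter. Among the compounds with values here, a single step cannot show how far such a trend runs, and no measured compound shows where it might end or reverse. A further fall in the number is therefore expected, though a much smaller one that may not clear the scatter. The expected step is a 1.6-fold lower number from compound 2 to compound 3 (0.20 log units; within the scatter). Compound 3 is estimated at 0.5 ug/mL, with an expected range from 0.1 ug/mL to 2.5 ug/mL.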

Compound 3, half-maximal inhibitory concentration: 6 ug/mL
Estimate against measurement, compound 3: 12-fold (1.08 log units) below; the whole stated range lies below it.
By their numbers in this assay, from the lowest: compound 2; then compound 3; then compound 1.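

In this assay the replacement of phenoxy by 2-phenoxyethyl does not act alike along the chain: made five bonds along it, the change gave a 22-fold lower number from compound 1 to compound 2 (1.34 log units; beyond the scatter), but made seven bonds along it, the change gave a 7.5-fold higher number from compound 2 to compound 3 (0.88 log units; beyond the scatter). Extending the chain therefore does not keep lowering the number, and among the three compounds shown the direction reverses, with compound 2 at the lowest point and compound 3 going against any simple trend with length. No measurement offered here accounts for this reversal.

From the compounds shown here alone, whether a chain of intermediate length, falling between those of compound 1 and compound 3, would give a number lower than that of compound 2 remains open, so the true low point may not lie at compound 2. Also open, going by these compounds, is whether a longer chain would raise the number further, and whether the same reversal would appear if an amine or a carboxylic acid stood in place of phenoxy at the end of the chain.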